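Iodo for bromo on the 4-bromophenyl ring of compound 2

This account rests on a few compounds, and the source may have more. Where it says the series, first, only, none or still open, it means among the compounds named here.

Compound 1, `O=C(N/N=C/c1cc(I)c(O)c(I)c1)c1ccccc1`, in a functional assay on HepG2 cells (Homo sapiens) for cytotoxicity, with a stated time of 24 h; on this read-out higher numbers stand for weaker inhibition and lower numbers for stronger inhibition: 191000 nM.
Compound 2, `O=C(N/N=C/c1cc(I)c(O)c(I)c1)c1ccc(Br)cc1`, in this assay: > 50000 nM.

Compound 2 is only known by the limit of this assay; its entry is a limit, not a number (the limit of > 50000 nM in this assay, at which 1 of the 2 values shown sits). Among the measured compounds shown here, for this reason the single measured step, a step that the limit leaves unreadable from compound 1 to compound 2, cannot be read for size or direction. Compound 3, `O=C(N/N=C/c1cc(I)c(O)c(I)c1)c1ccc(I)cc1`, differs from compound 2 by iodo in place of bromo on an aromatic carbon. For the measured compounds named here, no measured step concerns an exchange of one halogen for another on this ring; the only step available, a step that the limit leaves unreadable from compound 1 to compound 2, is unreadable and so gives no guide beyond placing compound 2 in the weak region of this assay. Compound 3 is therefore expected to stay in that same weak region, with an expected step that the limit leaves unreadable from compound 2 to compound 3 that is not distinguishable from the scatter. The estimate for compound 3 in this assay is 100000 nM, with a range from 40000 nM to 250000 nM, and a real chance that only a limit is reported again.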

Compound 3, half-maximal inhibitory concentration: > 50000 nM
Compound 3: no number, only a limit; the forecaster's own chance of this, stated with the estimate: 60%; the middle value is on the limit's open side.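

Compound 2 and compound 3 both stand only as limits in this assay, so no step among them or from compound 1 can be read: the limit of > 50000 nM in this assay, at which 2 of the 3 values shown sit.

From the compounds shown here alone, how compound 2 and compound 3 compare with compound 1, and whether bromo and iodo differ on this ring, stays open.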